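Methyl on the aryl ring, carried into the oxanyl series

A few compounds are considered here, and "the series" means these few. Any claim that something is new, unique, unknown or untested is made for them only; others in the source may bear on it.

Measured so far in an assay on isolated protein for binding affinity to melanin-concentrating hormone receptor 1 (Homo sapiens); a higher number here means a weaker inhibitor, a lower number a stronger inhibitor:
compound 1, `Cc1ccc(-c2cc3ncn([C@H]4CCN(C(=O)N(C)[C@H]5CCN(C)C5)C4)c(=O)c3s2)cc1`: 15 nM
compound 2, `Cc1ccc(-c2cc3ncn([C@H]4CCN(C(=O)N(C)[C@H]5CCN(C)C5)C4)c(=O)c3s2)c(C)c1`: 49 nM
compound 3, `Cc1ccc(-c2cc3ncn([C@H]4CCN(C(=O)N(C)[C@H]5CCN(C6CCOCC6)C5)C4)c(=O)c3s2)cc1`: 14 nM

Compound 3 stands at the low end of the three numbers in this assay; compound 1 lies within the scatter of it, as the step of a 1.1-fold lower number from compound 1 to compound 3 (0.03 log units; within the scatter) shows, while compound 2 sits further off, beyond the scatter. The change of the ring-amine substituent, oxan-4-yl in place of methyl, thus left the number essentially unchanged.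

Compound 4, `Cc1ccc(-c2cc3ncn([C@H]4CCN(C(=O)N(C)[C@H]5CCN(C6CCOCC6)C5)C4)c(=O)c3s2)c(C)c1`, has not yet been measured. It is compound 3 with methyl in place of hydrogen on an aromatic carbon. Within the data shown here, one measured step bears directly on this: a 3.3-fold higher number from compound 1 to compound 2 (0.51 log units; beyond the scatter), the same methyl addition made on the core carrying the methyl-bearing ring amine. Since the oxanyl change from compound 1 to compound 3 did not move the number beyond the scatter, the methyl step is expected to carry over to the oxanyl pair at about the same size and in the same direction, toward a higher number. The estimated step in this assay is a 3.3-fold higher number from compound 3 to compound 4 (0.52 log units; beyond the scatter). Compound 4 is accordingly expected to give 46 nM, with a range of 20 nM to 110 nM.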

Compound 4, inhibition constant: 70 nM
Estimate against measurement, compound 4: 1.5-fold (0.18 log units) below, and the stated range covers the measured number.
By their numbers in this assay, from the lowest: compounds 3 and 1 (each within the scatter of the next); then compounds 2 and 4 (each within the scatter of the next).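

In this assay, the change from 4-methylphenyl to 2,4-dimethylphenyl now has a second reading, a 5.0-fold higher number from compound 3 to compound 4 (0.70 log units; beyond the scatter), so the rise in the number at this carbon, ortho to a large group, is not confined to the core with the methyl-bearing ring amine; the two readings agree in direction and size: the same change on two cores in this assay, a 3.3-fold higher number (0.51 log units; beyond the scatter) from compound 1 to compound 2 and a 5.0-fold higher number (0.70 log units; beyond the scatter) from compound 3 to compound 4, 1.5-fold (0.18 log units) apart, within the scatter of two such steps. The ring-amine change has also been read on the second aryl group, where a 1.4-fold higher number from compound 2 to compound 4 (0.15 log units; within the scatter) shows that oxan-4-yl in place of methyl leaves the number within the scatter on the 2,4-dimethylphenyl core as well: the same change on two cores in this assay, a 1.1-fold lower number (0.03 log units; within the scatter) from compound 1 to compound 3 and a 1.4-fold higher number (0.15 log units; within the scatter) from compound 2 to compound 4, 1.5-fold (0.18 log units) apart, within the scatter of two such steps. Across these four compounds, the two changes therefore read as independent of each other, and no compound goes against this.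

The compounds shown leave open whether the rise belongs to this place on the aromatic ring or to methyl itself, which a chlorine, a fluorine or a methoxy group at the same carbon would help to separate. They also leave open whether the ring-amine nitrogen stays as undemanding with an acetyl group or a chain ending in a carboxylic acid.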